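This account rests on a few compounds, and the source may have more. Where it says the series, first, only, none or still open, it means among the compounds named here.

The measured compounds in a functional assay on HepG2 cells (Homo sapiens) for antiproliferative activity, read by MTT assay, with a stated time of 48 h; on this read-out higher numbers stand for weaker inhibition and lower numbers for stronger inhibition: compound 1 `CCCCCCOc1ccc(C(=O)/C=C/c2c(/C=C/c3ccc(OC)cc3)cc(OC)cc2OC)cc1` gives 16.2 ug/mL; compound 2 `CCCC(C)Oc1ccc(C(=O)/C=C/c2c(/C=C/c3ccc(OC)cc3)cc(OC)cc2OC)cc1` gives 11.1 ug/mL; compound 3 `COc1ccc(/C=C/c2cc(OC)cc(OC)c2/C=C/C(=O)c2ccc(OC)cc2)cc1` gives 4.9 ug/mL.

Compound 1 has the highest number of the three, though its gap to compound 2, a 1.5-fold lower number from compound 1 to compound 2 (0.16 log units; within the scatter), is within the scatter, while its gap to compound 3, a 3.3-fold lower number from compound 1 to compound 3 (0.52 log units; beyond the scatter), is a modest step beyond it. Compound 4 `COc1ccc(/C=C/c2cc(OC)cc(OC)c2/C=C/C(=O)c2ccc(C)cc2)cc1` arises from compound 1 by one change: methyl in place of hexyloxy on an aromatic carbon. Going by the values given here, the steps that bear on it are the two that shortened the chain on that oxygen, a 3.3-fold lower number from compound 1 to compound 3 (0.52 log units; beyond the scatter) and a 2.3-fold lower number from compound 2 to compound 3 (0.36 log units; beyond the scatter), both modest lowerings. Among the compounds with values here, no measured step removes the oxygen itself, so that part of the change is unguided. A modest lowering in this assay is therefore expected. Compound 4 is estimated at 6.5 ug/mL, from 3 ug/mL to 14 ug/mL, which would be a step of a 2.5-fold lower number from compound 1 to compound 4 (0.40 log units; beyond the scatter).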

Compound 4, half-maximal inhibitory concentration: 4.8 ug/mL
The estimate for compound 4 lay 1.4-fold (0.13 log units) above the measured number; measured number inside the range.
By their numbers in this assay, from the lowest: compounds 4 and 3 (each within the scatter of the next); then compounds 2 and 1 (each within the scatter of the next).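

In this assay the oxygen on this aromatic carbon proves dispensable, since methyl in place of methoxy gives a 1.0-fold lower number from compound 3 to compound 4 (0.01 log units; within the scatter) and leaves the two compounds indistinguishable. Methyl also keeps the gain seen with methoxy over the larger groups, giving a 3.4-fold lower number from compound 1 to compound 4 (0.53 log units; beyond the scatter) and a 2.3-fold lower number from compound 2 to compound 4 (0.36 log units; beyond the scatter). Among these four compounds, the small groups at this place therefore go with the lower numbers. Nothing measured here gives a reason for these steps. As far as these compounds go, whether a hydroxyl, a chlorine atom or an amine at this place would give a similar number remains open.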